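Removing a Methoxy Group on a Phenyl Ring

The compounds below may be only part of what the source reports. "The series", "measured", "known", "first", "only" and "open" are said of these compounds alone.

Measured compounds:
compound 1 `O=c1[nH]nc2n(c1=O)CCN2c1ccccc1` gives 0%
compound 2 `COc1ccc(N2CCN/C2=N\N)cc1` gives 23%
compound 3 `COc1ccccc1N1CCn2c1n[nH]c(=O)c2=O` gives 9%

In a functional assay on T47D cells (Homo sapiens) for cytotoxicity, with a stated time of 72 h, tested at 50 ug/mL (on this read-out lower numbers stand for a weaker effect and higher numbers for a stronger effect at the one concentration tested), compound 2 gives the highest number of the three; the gaps to compound 3 and to compound 1 both lie beyond the usual scatter. Compound 4 `N/N=C1\NCCN1c1ccccc1` has not been measured yet. It differs from compound 2 by hydrogen in place of methoxy on an aromatic carbon. The same kind of change is seen between compound 3 and compound 1, where it reads (hydrogen in place of methoxy on an aromatic carbon); the two changes are the same kind but not the same, since in compound 2 the methoxy sits para to a group of 7 heavy atoms, while in compound 3 it sits ortho to a large group. The measured step was a number 9 percentage points lower from compound 3 to compound 1 (within the scatter). The difference between the cores of compound 2 and compound 3 is not broken down here. Beside that earlier step, compound 4 is expected to show a step of a number 7 percentage points lower from compound 2 to compound 4 (within the scatter), an estimate resting on the measured step of a number 9 percentage points lower from compound 3 to compound 1 (within the scatter) being within the scatter. Compound 4 is therefore estimated at 16%, between 2% and 32%.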

Compound 4, a percentage reported as inhibition, at one concentration (the size of the read-out at that concentration, not a potency): 0%
Estimate against measurement, compound 4: 16 percentage points above; the measured number lies below the stated range.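

In this assay, taking the methoxy group off the aromatic ring gives a number 23 percentage points lower from compound 2 to compound 4 (beyond the scatter), a step larger than the scatter on this core, where the methoxy sits para to a group of 7 heavy atoms. Set beside the same change on the other core, this step cannot be told apart from it: the same change on two cores in this assay, a number 9 percentage points lower (within the scatter) from compound 3 to compound 1 and a number 23 percentage points lower (beyond the scatter) from compound 2 to compound 4, 14 percentage points apart, within the scatter of two such steps. Among the compounds shown here, this shows that the two steps are compatible with one effect of the change on both cores, but it does not show that the size of the step carries over, since the evidence is only two pairs, the methoxy does not stand in the same place in compound 2 and compound 3, and only one of the steps clears the scatter.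

The compounds shown leave open whether another group in place of the methoxy, such as an amine, a carboxylic acid or a longer alkoxy chain, would keep or raise the read-out on either core. They also leave open whether the effect of these compounds would be stronger or weaker at any other concentration, as each was read at one concentration only.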